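Chloro Added to an Aromatic Carbon of Compound 2

The source may hold more compounds than are shown below. What is called first, only, known or untested is meant among the compounds shown, and "the series" means these compounds.

Compound 1, `CCCS(=O)(=O)Nc1cccc2c1CCCC2c1c[nH]cn1`: in an assay on isolated protein (Cricetulus griseus) for binding affinity to Alpha-1B adrenergic receptor (Mesocricetus auratus), read by radioligand binding (on this read-out higher numbers stand for weaker inhibition and lower numbers for stronger inhibition), compound 1 gives < 10000 nM, which is a limit of the assay and not a number.
Compound 2, `CCS(=O)(=O)Nc1cccc2c1CCCC2c1c[nH]cn1`: compound 2 gives 1320 nM.
Compound 3, `CCS(=O)(=O)Nc1cccc2c1CCCC2CNC`: compound 3 gives < 10000 nM, again a limit of the assay.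

Among the compounds with values here, compound 2 thus holds the only real number; the other two values sit at the limit of < 10000 nM in this assay, at which 2 of the 3 values shown sit. Compound 4, `CCS(=O)(=O)Nc1cc(Cl)cc2c1CCCC2c1c[nH]cn1`, differs from compound 2 by chloro in place of hydrogen on an aromatic carbon. The two measured steps, a step that the limit leaves unreadable from compound 1 to compound 2 and a step that the limit leaves unreadable from compound 2 to compound 3, change the chain or the saturated ring carbon, not the aromatic ring, and both are unreadable, so neither gives a direction for this change. The expected step is therefore a 1.3-fold lower number from compound 2 to compound 4 (0.12 log units; within the scatter), meaning no shift beyond the scatter. Compound 4 is estimated at 1000 nM, within 200 nM to 6000 nM.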

Compound 4, inhibition constant: < 10000 nM
Compound 4: a limit, no number; the forecaster's own chance of this, stated with the estimate: 15%; the middle value lies beyond the limit too.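

The value of compound 4 is a limit of the assay and not a number, and the change from compound 2 to compound 4 cannot be read. The compounds shown leave open how far, and in which direction, chloro in place of hydrogen on this aromatic carbon moves the result.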